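The source may hold more compounds than are shown below. What is called first, only, known or untested is meant among the compounds shown, and "the series" means these compounds.

Of the compounds shown here, two built on a shared core have been measured in an assay on HEK293 cells for inhibition of Voltage-dependent T-type calcium channel subunit alpha-1G (Homo sapiens), read by fluorescence, tested at 10 uM; a higher number here means more inhibition at the concentration tested (going by the name of the read-out), a lower number less inhibition. Compound 1 `CCCc1nc(-c2ccccc2)c(CNCCN2CCN(c3ccccc3F)CC2)o1` gives 46.5% in this assay. Compound 2 `CCCc1nc(-c2ccccc2)c(CNCCCN2CCN(c3ccccc3C(F)(F)F)CC2)o1` gives 45% in this assay, a number that lies within the usual scatter of that of compound 1, so the two cannot be told apart on these measurements. Compound 1 is one of two compounds sitting at a similar level of inhibition; nothing here separates it from compound 2. Compound 3 `CCCc1nc(-c2ccccc2)c(CNCCN2CCN(c3cccc(C)c3C)CC2)o1` has not yet been measured. It differs from compound 1 in one place: 2,3-dimethylphenyl in place of 2-fluorophenyl on an amine nitrogen in a ring. Within the data shown here, no measured pair shows what such a change does, so the expected step from compound 1 to compound 3 is a number 1.5 percentage points lower from compound 1 to compound 3 (within the scatter), that is, none beyond the scatter. Compound 3 is therefore estimated to give 45% in this assay, with a range from 25% to 65%.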

Compound 3, a percentage reported as inhibition, at one concentration (the size of the read-out at that concentration, not a potency): 66.7%
For compound 3 the middle estimate is 21.7 percentage points below the measured one; the whole stated range lies below it.
By their numbers in this assay, from the lowest: compounds 2 and 1 (each within the scatter of the next); then compound 3.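

In this assay, putting 2,3-dimethylphenyl in place of 2-fluorophenyl on the amine nitrogen in the ring gives a number 20.2 percentage points higher from compound 1 to compound 3 (beyond the scatter), so what sits at this position can move the read-out. The earlier compounds shown here could not show this, as they differ in more than one place; here, both groups have one six-membered aromatic ring of carbon only, with no hydrogen-bond donors or acceptors and no net charge. Nothing available explains the rise.

Going by these compounds, with a single pair, it remains open whether the two methyl groups are both needed or whether the loss of fluorine also plays a part. On these data alone, a phenyl ring carrying one methyl group, a chlorine or a methoxy group would be needed to separate these possibilities, and the same change on the longer chain of compound 2 also remains open.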